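Series notes: dihydroxyphenyl analogue of compound 2

A few compounds are considered here, and "the series" means these few. Any claim that something is new, unique, unknown or untested is made for them only; others in the source may bear on it.

Measured so far in a functional assay on cells (Cancer cell lines, Homo sapiens) for cytotoxicity, read by sulforhodamine B assay, with a stated time of 48 h; a higher number here means a weaker inhibitor of growth, a lower number a stronger inhibitor of growth:
compound 1 `COc1ccc(OC)c(-c2cc(-c3ccccc3)nn2-c2ccc(S(N)(=O)=O)cc2)c1` gives 28800 nM
compound 2 `COc1ccc(OC)c(-c2cc(-c3ccccc3)nn2-c2ccc(S(=O)(=O)NC(C)=O)cc2)c1` gives 28800 nM
compound 3 `COc1ccc(OC)c(-c2cc(-c3ccc(Cl)cc3)nn2-c2ccc(S(=O)(=O)NC(C)=O)cc2)c1` gives 21900 nM

Compound 2 stands level with compound 1 at the digits shown, the pair forming the highest numbers of the three, and compound 3 lies nearest below it. The two measured steps are both small: no change at the digits printed from compound 1 to compound 2 (within the scatter), and a 1.3-fold lower number from compound 2 to compound 3 (0.12 log units; within the scatter). Neither touches the dimethoxyphenyl group.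

Compound 4 `CC(=O)NS(=O)(=O)c1ccc(-n2nc(-c3ccccc3)cc2-c2cc(O)ccc2O)cc1` differs from compound 2 by 2,5-dihydroxyphenyl in place of 2,5-dimethoxyphenyl on an aromatic carbon. Within the data shown here, no measured step bears on this change, so no direction can be taken from the data; the only guidance is that the two steps measured in this assay were both within the scatter, which gives no reason to expect a large movement. Compound 4 is therefore expected to show a 1.2-fold lower number from compound 2 to compound 4 (0.06 log units; within the scatter), with a wide range to reflect the absence of any matched step.

Estimate for compound 4 in this assay: 25000 nM, within 8000 nM to 70000 nM.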

Compound 4, concentration for total growth inhibition: 100000 nM
Compound 4: middle estimate off by 4.0-fold (0.60 log units), on the low side, outside the stated range (above it).
By their numbers in this assay, from the lowest: compounds 3, 1 and 2 (each within the scatter of the next); then compound 4.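

In this assay, among these compounds, 2,5-dihydroxyphenyl in place of 2,5-dimethoxyphenyl gives a 3.5-fold higher number from compound 2 to compound 4 (0.54 log units; beyond the scatter), the first step in this set to lie beyond the scatter. The earlier steps shown here, at the sulfonamide nitrogen and on the phenyl group, left the number within the scatter, whereas this aromatic carbon next to the ring nitrogen shows that a change to its substituent can weaken growth inhibition. Nothing measured here accounts for this step.

Still open, from the compounds shown here alone, is whether a phenyl group carrying one hydroxy and one methoxy group would follow compound 2 or compound 4, and whether an ethoxy or amino group would behave like either. Also open, going by these compounds, is whether the same exchange gives a similar step with the chloro group of compound 3 or the free sulfonamide of compound 1.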